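Exchanging the diethylamino Group: Expected Cytotoxicity of Compound 4

A few compounds are considered here, and "the series" means these few. Any claim that something is new, unique, unknown or untested is made for them only; others in the source may bear on it.

Compound 2 `CCN(CC)CC(=O)Nc1ccc(-c2nc3cc(C(F)(F)F)ccc3n2C)cc1` was examined in an ADME assay on MT4 cells (Homo sapiens) for cytotoxicity, read by MTT assay, with a stated time of 96 h (a higher number here means that more compound is tolerated, a lower number that less compound is tolerated), where compound 2 gives 9000 nM. For the measured compounds named here, of the three numbers measured so far, this stands second highest. Compound 1 `CC(=O)Nc1ccc(-c2nc3cc(C(F)(F)F)ccc3n2C)cc1` gives 15000 nM in this assay, and compound 3 `CCN(CC)CC(=O)Nc1ccc(-c2nc3cc(C(F)(F)F)ccc3[nH]2)cc1` gives 8000 nM. The step of a 1.7-fold lower number from compound 1 to compound 2 (0.22 log units; within the scatter) and the step of a 1.1-fold lower number from compound 2 to compound 3 (0.05 log units; within the scatter) both stay within the scatter, so the three measured compounds cannot be told apart on this read-out.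

Compound 4 `Cn1c(-c2ccc(NC(=O)CN3CCN(c4ccccc4)CC3)cc2)nc2cc(C(F)(F)F)ccc21` awaits measurement. Its difference from compound 2 is this: 4-phenylpiperazin-1-yl in place of diethylamino on a saturated chain carbon bound to a carbonyl carbon

Of the measured steps, only a 1.7-fold lower number from compound 1 to compound 2 (0.22 log units; within the scatter) touches the same place, the saturated chain carbon bound to a carbonyl carbon, and it stayed within the scatter; a 1.1-fold lower number from compound 2 to compound 3 (0.05 log units; within the scatter) concerns the aromatic nitrogen and says nothing about this position. With one step at the relevant place and no change beyond the scatter in it, no step beyond the scatter is expected from compound 2 to compound 4, and the estimated step is no change at the digits printed from compound 2 to compound 4 (within the scatter). Compound 4 is therefore expected to give about 9000 nM in this assay, with a likely range from 3500 nM to 22000 nM.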

Compound 4, half-maximal cytotoxic concentration: 1500 nM
Compound 4: the middle estimate sits 6.0-fold (0.78 log units) above what was measured, outside the stated range (below it).
By their numbers in this assay, from the lowest: compound 4; then compounds 3, 2 and 1 (each within the scatter of the next).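

In this assay, for the compounds shown here, the chain carbon bound to the carbonyl carbon turns out to be a place where a change can be read: the exchange of diethylamino for 4-phenylpiperazin-1-yl brings a 6.0-fold lower number from compound 2 to compound 4 (0.78 log units; beyond the scatter) and so passes beyond the scatter, which no earlier step had done. Set against the hydrogen of compound 1, the same group gives a 10-fold lower number from compound 1 to compound 4 (1.00 log units; beyond the scatter) while diethylamino at this carbon stayed within the scatter of that hydrogen, so on this read-out the outcome depends on which group enters here and not merely on the presence of a substituent. Nothing available on the compounds gives a reason for this result.

The entering group adds both a six-membered non-aromatic ring with two nitrogens and a phenyl ring, and a piperidin-1-yl or 4-methylpiperazin-1-yl group on the same carbon would be needed to tell which of the two goes with the step. On these data alone, it also remains open whether 4-phenylpiperazin-1-yl acts the same way when hydrogen replaces methyl on the aromatic nitrogen, as in compound 3.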